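A few compounds are considered here, and "the series" means these few. Any claim that something is new, unique, unknown or untested is made for them only; others in the source may bear on it.

Going by the values given here, compound 2 `CNCc1cc(=O)oc2cc(OCc3ccccc3)ccc12` is the lower of the two numbers so far, but only by a 1.5-fold lower number from compound 1 to compound 2 (0.18 log units; within the scatter) from compound 1 `CN(C)C(=O)Cc1cc(=O)oc2cc(OCc3ccccc3)ccc12`. In an assay (strain Wistar) for inhibition of Amine oxidase [flavin-containing] A (Rattus norvegicus) (a lower number here means a stronger inhibitor, a higher number a weaker inhibitor), compound 1 gives 23100 nM and compound 2 gives 15400 nM; the two sit within the scatter of each other. Compound 3 `CN(C)Cc1cc(=O)oc2cc(OCc3ccccc3)ccc12` differs from compound 2 by methyl in place of hydrogen on an amine nitrogen. Among the compounds with values here, no measured step touches this nitrogen alone; the one step known reshaped the whole side chain and stayed within the scatter. The expected step is therefore small, a 1.0-fold lower number from compound 2 to compound 3 (0.01 log units; within the scatter), with no direction claimed. Compound 3 is estimated at 15000 nM, in the range 6000 nM to 40000 nM.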

Compound 3, half-maximal inhibitory concentration: 100000 nM
Beside the measured number, compound 3's estimate is 6.7-fold (0.82 log units) below it, outside the stated range (above it).
By their numbers in this assay, from the lowest: compounds 2 and 1 (each within the scatter of the next); then compound 3.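

In this assay, going by these compounds alone, the amine nitrogen proves sensitive: methyl in place of hydrogen gives a 6.5-fold higher number from compound 2 to compound 3 (0.81 log units; beyond the scatter) and is the first change to go beyond the scatter, although the earlier reshaping of the whole side chain did not. Dimethylamino in place of dimethylcarbamoyl also gives a 4.3-fold higher number from compound 1 to compound 3 (0.64 log units; beyond the scatter) in a weaker direction, so the dimethylamino side chain stands apart from both others. Nothing at hand gives a reason for either step. Still open, as far as these compounds go, is whether ethyl on this nitrogen, or a morpholine ring in place of the amine, would follow the methyl. From the compounds shown here alone, a longer chain carrying the methylamino group is equally open.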